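Benzothiazole series: methoxy to chloro on the central ring

The source may report more compounds than this note shows. Statements on the series, on what has been measured and on what is new or still open speak of the compounds shown alone.

Measured compounds:
- compound 1 `NC(=O)c1cc(NS(=O)(=O)c2ccc(F)cc2)cc(-c2ccc3nc(NC(=O)C4CC4)sc3c2)c1`: in a functional assay on U-87MG ATCC cells (Homo sapiens) for antiproliferative activity, read by MTT assay, with a stated time of 72 h (on this read-out lower numbers stand for stronger inhibition and higher numbers for weaker inhibition), compound 1 gives "not determined" (no result reported)
- compound 2 `COc1c(NS(=O)(=O)c2ccc(F)cc2)cc(-c2ccc3nc(NC(=O)C4CC4)sc3c2)cc1C(N)=O`: 2870 nM

Compound 2 stands alone with a number in this assay; for compound 1 no value was recorded, so no comparison between the two can be drawn. Compound 3 `NC(=O)c1cc(-c2ccc3nc(NC(=O)C4CC4)sc3c2)cc(NS(=O)(=O)c2ccc(F)cc2)c1Cl` differs from compound 2 by chloro in place of methoxy on an aromatic carbon. Among the measured compounds shown here, with no measured step of this kind available, only a modest shift beyond the scatter, in either direction, is expected for this assay; the estimated step is a 1.1-fold lower number from compound 2 to compound 3 (0.06 log units; within the scatter). Compound 3 is therefore expected to give 2500 nM, within a range from 900 nM to 7000 nM.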

Compound 3, half-maximal inhibitory concentration: 17900 nM
Estimate against measurement, compound 3: 7.2-fold (0.85 log units) below, outside the stated range (above it).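

In this assay, the position ortho to the ((4-fluorophenyl)sulfonyl)amino group and ortho to the carbamoyl group proves sensitive to its substituent: chloro in place of methoxy gives a 6.2-fold higher number from compound 2 to compound 3 (0.79 log units; beyond the scatter). Among the compounds shown here, this is the first readable step, and it runs toward weaker inhibition. No available evidence bears on the reason for this loss. From the compounds shown here alone, whether an amine or an ethoxy group at this position would retain the activity of compound 2 remains open. Also open, going by these compounds, is how either substituent compares with hydrogen, since compound 1 gives "not determined" (no result reported).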